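Replacing 4-Hydroxyphenyl with 2-Phenylethenyl on Compound 1

The source may hold more compounds than are shown below. What is called first, only, known or untested is meant among the compounds shown, and "the series" means these compounds.

In an ADME assay on HEL cells (Homo sapiens) for cytotoxicity (on this read-out higher numbers stand for lower toxicity in this test and lower numbers for higher toxicity in this test), compound 1 `O=C(COc1cccc2ccccc12)N/N=C/c1ccc(O)cc1` gives 60.6 ug/mL. Compound 2 `C/C(=N\NC(=O)COc1cccc2ccccc12)c1cccc([N+](=O)[O-])c1` gives 10.5 ug/mL, which leaves compound 1 with the higher of the two numbers, by a gap beyond the usual scatter. Compound 3 `O=C(COc1cccc2ccccc12)N/N=C/C=C/c1ccccc1` has not yet been measured. It departs from compound 1 in one place: 2-phenylethenyl in place of 4-hydroxyphenyl on a carbon with a double bond to nitrogen. In words, 2-phenylethenyl stands in place of 4-hydroxyphenyl on a carbon with a double bond to nitrogen. Among the compounds with values here, no measured pair differing in one place is available as a guide in this assay. The expectation therefore rests only on compound 1 at 60.6 ug/mL and compound 2 at 10.5 ug/mL. A downward move is expected, and the estimated size is a 2.2-fold lower number from compound 1 to compound 3 (0.34 log units; beyond the scatter). For compound 3 the expected value is 28 ug/mL, with an estimated range from 9 ug/mL to 85 ug/mL.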

Compound 3, half-maximal cytotoxic concentration: 100 ug/mL
Compound 3: the middle estimate sits 3.6-fold (0.55 log units) below what was measured, and the stated range ends below it.
By their numbers in this assay, from the lowest: compound 2; then compounds 1 and 3 (each within the scatter of the next).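

In this assay the exchange of 4-hydroxyphenyl for 2-phenylethenyl on a carbon with a double bond to nitrogen gives a 1.7-fold higher number from compound 1 to compound 3 (0.22 log units; within the scatter) and leaves compound 1 and compound 3 indistinguishable on this read-out. This position therefore takes the exchange without a separable shift in the number, even though the hydrogen-bond donor and acceptor counted for 4-hydroxyphenyl leave and a double bond outside aromatic rings enters. No measurement at hand accounts for this result.

As far as these compounds go, it remains open whether the double bond outside aromatic rings matters here, which a plain phenyl or a saturated 2-phenylethyl group could test, and how an amine or a carboxylic acid in place of the hydroxyl would read. Compound 2 differs from compound 1 in more than one place, so its lower value cannot be tied to any single change.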